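A pyridin-2-yl exchange on the shared core

The source may report more compounds than this note shows. Statements on the series, on what has been measured and on what is new or still open speak of the compounds shown alone.

compound 1 `O=C(/C=C/c1ccc(O)c(O)c1)N1CCN(c2ccccc2Cl)CC1`: 1.82 ug/mL
compound 2 `O=C(/C=C/c1ccc(O)c(O)c1)N1CCN(c2ccc(Cl)c(Cl)c2)CC1`: 1.66 ug/mL
compound 3 `O=C(/C=C/c1ccc(O)c(O)c1)N1CCN(c2ccccn2)CC1`: not yet measured

In a functional assay on B16-F10 cells (Mus musculus) for antiproliferative activity, read by MTT assay, with a stated time of 48 h (a lower number here means a stronger inhibitor, a higher number a weaker inhibitor), compound 2 stands level with compound 1, within the scatter. In compound 3, pyridin-2-yl takes the place of 3,4-dichlorophenyl on an amine nitrogen in a ring (pyridin-2-yl in place of 3,4-dichlorophenyl on an amine nitrogen in a ring). Among the compounds with values here, the one measured step, a 1.1-fold lower number from compound 1 to compound 2 (0.04 log units; within the scatter) stayed within the scatter, but it only exchanged one chlorinated phenyl for another. Within the data shown here, no measured step tests a ring nitrogen. The expected change is therefore small, a 1.5-fold higher number from compound 2 to compound 3 (0.18 log units; within the scatter) and no shift clearly beyond the scatter is expected. In this assay compound 3 is estimated at 2.5 ug/mL with 1 ug/mL and 6.5 ug/mL as the expected ends of its range.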

Compound 3, half-maximal inhibitory concentration: 3.01 ug/mL
For compound 3 the middle estimate is 1.2-fold (0.08 log units) below the measured one, and the stated range covers the measured number.
By their numbers in this assay, from the lowest: compounds 2, 1 and 3 (each within the scatter of the next).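

Within this assay this position now shows a change of aromatic ring rather than of chlorine pattern: pyridin-2-yl gives a 1.8-fold higher number from compound 2 to compound 3 (0.26 log units; within the scatter) and a 1.7-fold higher number from compound 1 to compound 3 (0.22 log units; within the scatter) when it replaces either chlorinated phenyl. Neither chlorine nor a ring of carbon only is therefore needed here for the number to stay within the scatter of compound 1 and compound 2. Nothing at hand explains these numbers. On these data alone, whether an aliphatic amine or a carboxylic acid on this ring nitrogen would move the number beyond the scatter remains open.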